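A few compounds are considered here, and "the series" means these few. Any claim that something is new, unique, unknown or untested is made for them only; others in the source may bear on it.

Measured compounds:
- compound 1, `CCCCCCCc1cn(C(c2ccccc2)c2cc3cc(Br)ccc3nc2OC)nn1`: 0.17%
- compound 2, `COc1nc2ccc(Br)cc2cc1C(c1ccccc1)n1cc(-c2ccc(F)cc2)nn1`: 4.04%
- compound 3, `COc1nc2ccc(Br)cc2cc1C(c1ccccc1)n1cc(CCO)nn1`: 4.54%

In an ADME assay on HEK293 cells (Homo sapiens) for cytotoxicity, read by sulforhodamine B assay, with a stated time of 48 h, tested at 10 uM (on this read-out higher numbers stand for more inhibition at the one concentration tested (going by the name of the read-out) and lower numbers for less inhibition), compound 3 gives the highest of the three numbers, yet the steps of a number 0.5 percentage points higher from compound 2 to compound 3 (within the scatter) and a number 4.4 percentage points higher from compound 1 to compound 3 (within the scatter) both lie within the scatter, so the three compounds cannot be told apart on this read-out. The same holds for a number 3.9 percentage points higher from compound 1 to compound 2 (within the scatter).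

Compound 4, `CCCCCc1cn(C(c2ccccc2)c2cc3cc(Br)ccc3nc2OC)nn1`, has not yet been measured. It differs from compound 3 as follows: propyl in place of hydroxy on a saturated chain carbon, two bonds along the chain from an aromatic carbon. For the measured compounds named here, the step that bears on it most directly is the one from compound 1 to compound 3, which exchanged pentyl for hydroxy at the same place and moved the number only within the scatter; the present change goes the other way, from hydroxy to a three-carbon chain. Going by the values given here, no measured step on this core has moved the number beyond the scatter, so for compound 4 no step beyond the scatter is expected in this assay, with an expected step of a number 2 percentage points lower from compound 3 to compound 4 (within the scatter).

Compound 4 is therefore estimated at 2.5%, within 0% to 10%.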

Compound 4, a percentage reported as inhibition, at one concentration (the size of the read-out at that concentration, not a potency): -2%
For compound 4 the middle estimate is 4.5 percentage points above the measured one; the whole stated range lies above it.
By their numbers in this assay, from the lowest: compounds 4, 1, 2 and 3 (each within the scatter of the next).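

In this assay the read-out shows a number 6.5 percentage points lower from compound 3 to compound 4 (within the scatter), so exchanging hydroxy for propyl on the saturated chain carbon, two bonds along the chain from an aromatic carbon, does not produce a step beyond the scatter. The 4-pentyl-1H-1,2,3-triazol-1-yl compound adds two more such steps, a number 2.2 percentage points lower from compound 1 to compound 4 (within the scatter) and a number 6 percentage points lower from compound 2 to compound 4 (within the scatter), so the shorter alkyl chain also cannot be told apart from heptyl or 4-fluorophenyl. Hydroxy-ended, alkyl and aryl groups at this place therefore give numbers that do not separate on this read-out.

On these data alone, whether an amine or a carboxylic acid at the chain end would give a step beyond the scatter remains open. No supporting data bear on this result.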